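Adding Bromo Beside the Iodo Group of Compound 1

This account rests on a few compounds, and the source may have more. Where it says the series, first, only, none or still open, it means among the compounds named here.

Among the measured compounds shown here, in a functional assay on SKW3 cells (Homo sapiens) for antiproliferative activity, read by WST assay, with a stated time of 3 days (on this read-out lower numbers stand for stronger inhibition and higher numbers for weaker inhibition), compound 1 `O=c1cc(I)n([C@@H]2O[C@H](CO)[C@@H](O)[C@H]2O)c(=O)[nH]1` gives 18900 nM, the only true number so far. Compound 2 `O=c1cc(NO)n([C@@H]2O[C@H](CO)[C@@H](O)[C@H]2O)c(=O)[nH]1` reads > 50000 nM, which is a limit of the assay and not a number. Compound 3 `O=Cc1cc(=O)[nH]c(=O)n1[C@@H]1O[C@H](CO)[C@@H](O)[C@H]1O` reads > 50000 nM, which is also a limit.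

The next compound to be tested is compound 4 `O=c1[nH]c(=O)n([C@@H]2O[C@H](CO)[C@@H](O)[C@H]2O)c(I)c1Br`. It keeps the iodo group of compound 1 and adds one atom: bromo in place of hydrogen on an aromatic carbon. The new bromo sits ortho to an iodo group.

For the measured compounds named here, no measured step makes this kind of change, so the evidence is only indirect. Swapping the iodo group for hydroxyamino gives an at least 2.6-fold higher number from compound 1 to compound 2 (0.42 log units; beyond the scatter). Swapping it for formyl gives an at least 2.6-fold higher number from compound 1 to compound 3 (0.42 log units; beyond the scatter). Both steps show that activity falls when the iodo group is lost, and compound 4 does not lose it. Neither step shows what a bromo in place of hydrogen does.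

In this assay, the expectation is therefore no step beyond the scatter, though a weaker result seems more likely than a stronger one. The expected step is a 1.3-fold higher number from compound 1 to compound 4 (0.12 log units; within the scatter). Compound 4 is estimated at 25000 nM, with an expected range of 7000 nM to 70000 nM.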

Compound 4, half-maximal inhibitory concentration: > 50000 nM
Compound 4 ended at the assay's limit; the forecaster's own chance of this, stated with the estimate: 35%; at least 2.0-fold (0.30 log units) between middle value and limit.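

In this assay compound 4 reads > 50000 nM, which is a limit of the assay and not a number. The new step is an at least 2.6-fold higher number from compound 1 to compound 4 (0.42 log units; beyond the scatter), so keeping the iodo group does not by itself keep the activity of compound 1: a bromo in place of hydrogen, ortho to an iodo group, is enough to weaken it with the iodo group untouched. Until now only replacing the iodo group itself had been seen to raise the number, and this result shows that this second ring carbon matters too, although the true size of the loss stays unknown since the comparison ends at the top of the measured range: the limit of > 50000 nM in this assay, at which 3 of the 4 values shown sit.

The compounds shown leave open whether this loss belongs to bromo in particular or to any group at this position, such as fluoro, methyl, an amine or a carboxylic acid. They also leave open whether any change at this carbon could give a lower number than compound 1 at 18900 nM.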